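The source may hold more compounds than are shown below. What is called first, only, known or untested is meant among the compounds shown, and "the series" means these compounds.

Measured compounds:
compound 1, `COc1cc2c(cc1OC)C(=O)/C(=C/c1ccc(CN(C)Cc3ccccc3)c(O)c1)O2`: 19.4%
compound 2, `COc1cc2c(cc1OC)C(=O)/C(=C/c1ccc(O)cc1)O2`: 12.1%

In an assay on cells for inhibition of Amine oxidase [flavin-containing] A (Homo sapiens), read by fluorescence, with a stated time of 30 min, tested at 10 uM (on this read-out higher numbers stand for more inhibition at the one concentration tested (going by the name of the read-out) and lower numbers for less inhibition), compound 1 gives 19.4%, the number shown higher of the two, while compound 2 gives 12.1%; the gap between them lies within the usual scatter, so the two compounds cannot be told apart on these data. Going by the values given here, no step between measured compounds that differ in one place is available, and compound 2 carries none of the group that varies here, so the measured pair gives no guide to the change that follows.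

Compound 3, `COc1cc2c(cc1OC)C(=O)/C(=C/c1ccc(CN3CCCCC3)c(O)c1)O2`, is still to be measured in this assay. It differs from compound 1 by piperidin-1-yl in place of benzyl(methyl)amino on a saturated chain carbon bound to an aromatic carbon. Among the compounds with values here, nothing among the measured compounds speaks for a shift beyond the scatter from such an exchange, so the expected step of a number 2.4 percentage points lower from compound 1 to compound 3 (within the scatter) is small in either direction. For compound 3 an inhibition near 17% is estimated, within a range from 5% to 32%.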

Compound 3, a percentage reported as inhibition, at one concentration (the size of the read-out at that concentration, not a potency): 15.3%
Compound 3: middle estimate off by 1.7 percentage points, on the high side; the measured number falls inside the stated range.
By their numbers in this assay, from the lowest: compounds 2, 3 and 1 (each within the scatter of the next).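

In this assay, the exchange of benzyl(methyl)amino for piperidin-1-yl on a saturated chain carbon bound to an aromatic carbon gives a number 4.1 percentage points lower from compound 1 to compound 3 (within the scatter). This first step at this position shows that the aromatic ring of carbon only in the leaving group can give way to a six-membered non-aromatic ring with 1 hetero atom without a difference these data can separate from the scatter. No measurement bears on the reason for this result.

The compounds shown leave open whether another amine at this place, such as morpholin-4-yl or dimethylamino, would give a number beyond the scatter of compound 1. They also leave open what a longer chain carrying the amine, or a carboxylic acid in place of the amine, would give.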